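A few compounds are considered here, and "the series" means these few. Any claim that something is new, unique, unknown or untested is made for them only; others in the source may bear on it.

Compound 2, `Cc1cc2nc(-c3cc4ccccc4[nH]c3=O)[nH]c2cc1C`, belongs to a small set of closely related structures examined in the same way. In a functional assay on NCI-H460 cells (Homo sapiens) for cytotoxicity, read by MTT assay, with a stated time of 48 h (a lower number here means a stronger inhibitor, a higher number a weaker inhibitor), compound 2 gives > 100000 nM, which is a limit of the assay and not a number. Compound 1, `Cc1ccc2[nH]c(=O)c(-c3nc4ccccc4[nH]3)cc2c1`, is its nearest neighbour in the set. In this assay compound 1 gives > 100000 nM, again a limit rather than a number. Compound 3, `COc1ccc2[nH]c(=O)c(-c3nc4cc(Br)ccc4[nH]3)cc2c1`, carries a methoxy group and a bromine in place of methyls. In this assay compound 3 gives > 100000 nM, likewise a limit. Compound 2 therefore stands nowhere in particular among the numbers shown, because the limit of > 100000 nM in this assay, at which 3 of the 3 values shown sit, holds for every one of them, and no ordering of the three can be drawn.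

Compound 4, `Cc1ccc2[nH]c(=O)c(-c3nc4cc(C)c(C)cc4[nH]3)cc2c1`, differs from compound 2 by methyl in place of hydrogen on an aromatic carbon. For the measured compounds named here, with all three measured compounds sitting at the limit, no step between measured compounds is available to guide an expectation. The account expects the step that the limit leaves unreadable from compound 2 to compound 4 to be none beyond the scatter, since the added methyl is a small change on a series that shows no measurable cytotoxicity. Compound 4 is estimated at 150000 nM, between 40000 nM and 500000 nM, with the most likely outcome being that the assay again reports only a limit.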

Compound 4, half-maximal inhibitory concentration: > 100000 nM
Compound 4: no number, only a limit; the forecaster's own chance of this, stated with the estimate: 80%; the middle value does not contradict the limit.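

No step can be read from compound 2 to compound 4, because the values of both compounds are limits of the assay and not numbers: the limit of > 100000 nM in this assay, at which 4 of the 4 values shown sit.

The compounds shown leave open whether any structure in this set has a measurable effect in this assay and what a single change on the shared core would do to it.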